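The source may report more compounds than this note shows. Statements on the series, on what has been measured and on what is new or still open speak of the compounds shown alone.

Measured so far:

Compound 1, `CC(C)C[C@H](N)c1cc(C(F)(F)F)ccc1N1CCN(C(=O)[C@@H]2NCC[C@@H]2c2ccc(Cl)cc2)CC1`, gives 2400 nM in a functional assay for antagonist activity at Melanocortin receptor 4 (Homo sapiens), read by cAMP accumulation; a higher number here means a weaker inhibitor, a lower number a stronger inhibitor.
Compound 2, `CCOC(=O)N1CC[C@H](c2ccc(Cl)cc2)[C@@H]1C(=O)N1CCN(c2ccc(C)cc2[C@@H](N)C(C)C)CC1`, gives 640 nM in this assay.

Of these two numbers, compound 2 holds the lower one, and the gap up to compound 1 lies beyond the scatter of repeated measurements, so compound 2 is the stronger inhibitor of the pair. Compound 1 differs from compound 2 in more than one place, so its two values show only that, not what any single change does.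

Compound 3, `Cc1ccc(N2CCN(C(=O)[C@@H]3NCC[C@@H]3c3ccc(Cl)cc3)CC2)c([C@@H](N)C(C)C)c1`, keeps the shared core of compound 2 and changes one thing: hydrogen in place of ethoxycarbonyl on an amine nitrogen in a ring. For the measured compounds named here, no measured pair shows this change on its own. Compound 1 also carries a bare hydrogen on that ring nitrogen and gives the weaker number. Compound 1 differs from compound 2 in another place as well, so its value alone does not show what the bare hydrogen does. A modest move toward a higher number is therefore expected, a 2.3-fold higher number from compound 2 to compound 3 (0.37 log units; beyond the scatter), though it could stay within the scatter. Compound 3 is estimated at 1500 nM, with a likely range from 500 nM to 5000 nM.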

Compound 3, half-maximal inhibitory concentration: 310 nM
Beside the measured number, compound 3's estimate is 4.8-fold (0.68 log units) above it; measured number outside the range, below it.
By their numbers in this assay, from the lowest: compound 3; then compound 2; then compound 1.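

In this assay, replacing the ethoxycarbonyl on the amine nitrogen of the five-membered ring with hydrogen gives a 2.1-fold lower number from compound 2 to compound 3 (0.31 log units; beyond the scatter), a modest step that lies beyond the scatter. For the compounds shown here, this pair is the first to show the change on its own, and it reveals that a bare hydrogen at this position goes with a stronger inhibitor, not a weaker one, so the ethoxycarbonyl and its five heavy atoms are not needed for this level of inhibition. No supporting measurement explains why the number falls with this change.

Among the compounds shown, this nitrogen carries only hydrogen or ethoxycarbonyl, so it remains open whether a small group such as methyl or acetyl would behave more like the hydrogen or more like the ethoxycarbonyl. The step also comes from a single pair, which leaves open whether removing the ethoxycarbonyl would shift the number in the same direction if the rest of the molecule carried the different groups seen in compound 1.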